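The compounds below may be only part of what the source reports. "The series", "measured", "known", "first", "only" and "open" are said of these compounds alone.

Values in an ADME assay on HPLF cells (Homo sapiens) for cytotoxicity, with a stated time of 48 h; a higher number here means that more compound is tolerated, a lower number that less compound is tolerated:

Compound 1, `Cc1c(C(=O)/C=C/c2cccc([N+](=O)[O-])c2)[n+]([O-])c2ccccc2[n+]1[O-]`: 18000 nM
Compound 2, `COc1ccc(/C=C/C(=O)c2c(C)[n+]([O-])c3ccccc3[n+]2[O-])cc1OC`: 156000 nM
Compound 3, `Cc1c(C(=O)/C=C/c2ccc(Cl)cc2)[n+]([O-])c2ccccc2[n+]1[O-]`: 12000 nM

Compound 3 stands at the low end of the three numbers in this assay; the number for compound 1 lies within the scatter of it, while compound 2 gives a number well beyond the scatter, so only compound 2 is clearly separated from compound 3.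

Compound 4, `Cc1ccc(/C=C/C(=O)c2c(C)[n+]([O-])c3ccccc3[n+]2[O-])cc1`, is not yet measured in this assay. It differs from compound 3 by methyl in place of chloro on an aromatic carbon. Among the measured compounds shown here, no measured pair shows this change, so there is no step on record to lean on. Given that compound 1 and compound 3 sit close together despite unlike groups on the outer ring, the step from compound 3 to compound 4 is expected to be small, a 1.3-fold higher number from compound 3 to compound 4 (0.10 log units; within the scatter), in no clear direction. Compound 4 is estimated at 15000 nM, with a range from 5000 nM to 45000 nM.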

Compound 4, half-maximal cytotoxic concentration: 23000 nM
Estimate against measurement, compound 4: 1.5-fold (0.19 log units) below; the measured number falls inside the stated range.
By their numbers in this assay, from the lowest: compounds 3, 1 and 4 (each within the scatter of the next); then compound 2.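

In this assay, methyl in place of chloro on an aromatic carbon, para to a large group, gives a 1.9-fold higher number from compound 3 to compound 4 (0.28 log units; within the scatter). Among the compounds shown here, this is the first step on record at this position, and it does not separate the 4-chlorophenyl and 4-methylphenyl compounds. No measurement bearing on a cause of this result is at hand. The compounds shown leave open whether an amine or a carboxylic acid at this position would give a step beyond the scatter. A single pair also cannot show whether the same change behaves alike on other outer rings.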